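Chlorine to nitro on the anilino-type ring: what to expect

The compounds below may be only part of what the source reports. "The series", "measured", "known", "first", "only" and "open" are said of these compounds alone.

Compound 2 `Cc1cc(Nc2cc(N3CCN(C)CC3)nc(Nc3ccc(Cl)cc3)n2)n[nH]1` gives 631 nM in a functional assay on A549 cells (Homo sapiens) for antiproliferative activity, read by CCK-8 assay, with a stated time of 72 h; on this read-out higher numbers stand for weaker inhibition and lower numbers for stronger inhibition. Its only companion, compound 1 `Cc1cc(Nc2cc(N3CCN(C)CC3)nc(Nc3cccc(Cl)c3)n2)n[nH]1`, gives 723 nM, and the step of a 1.1-fold lower number from compound 1 to compound 2 (0.06 log units; within the scatter) lies within the scatter, so the two numbers cannot be told apart. Compound 3 `Cc1cc(Nc2cc(N3CCN(C)CC3)nc(Nc3cccc([N+](=O)[O-])c3)n2)n[nH]1` has not yet been measured; it differs from compound 2 by 3-nitrophenyl in place of 4-chlorophenyl on a nitrogen on an aromatic ring. Going by the values given here, no measured step exchanges a chlorine for another group, and the one ring change seen, a 1.1-fold lower number from compound 1 to compound 2 (0.06 log units; within the scatter), stayed within the scatter. Compound 3 is therefore expected to show no shift beyond the scatter, a 1.1-fold higher number from compound 2 to compound 3 (0.05 log units; within the scatter). The estimate for compound 3 is 700 nM, with a range from 250 nM to 2000 nM.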

Compound 3, half-maximal inhibitory concentration: 926 nM
Beside the measured number, compound 3's estimate is 1.3-fold (0.12 log units) below it; the measured number falls inside the stated range.
By their numbers in this assay, from the lowest: compounds 2, 1 and 3 (each within the scatter of the next).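

In this assay, nitro in place of chloro on an aromatic carbon stays within the scatter (a 1.3-fold higher number from compound 1 to compound 3 (0.11 log units; within the scatter)), as does 3-nitrophenyl in place of 4-chlorophenyl (a 1.5-fold higher number from compound 2 to compound 3 (0.17 log units; within the scatter)). Going by these compounds alone, the earlier compounds compared only two chlorophenyl groups, whereas these steps show that a group with hydrogen-bond acceptors, absent from the chlorophenyl groups, also gives no change beyond the scatter on this nitrogen. No measured evidence here bears on the reason for these numbers. Still open, as far as these compounds go, is whether an amine or a carboxylic acid on this ring, or a plain phenyl, would also remain within the scatter.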